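This account rests on a few compounds, and the source may have more. Where it says the series, first, only, none or still open, it means among the compounds named here.

Values in a functional assay on DU-145 cells (Homo sapiens) for inhibition, read by trypan blue exclusion, with a stated time of 96 h; a lower number here means a stronger inhibitor of growth, a higher number a weaker inhibitor of growth:
- compound 1 `Cc1ccc(S/C(=C/c2ccc(Cl)cc2)C(=O)c2ccc(Br)cc2)cc1`: 10000 nM
- compound 2 `Cc1ccc(S(=O)(=O)/C(=C/c2ccc(Oc3ccccc3)cc2)C(=O)c2ccc(Cl)cc2)cc1`: 1000 nM
- compound 3 `Cc1ccc(S/C(=C/c2ccc(Oc3ccccc3)cc2)C(=O)c2ccc(Cl)cc2)cc1`: 10000 nM

Compound 3, at 10000 nM, is level with compound 1, and together they hold the highest number of the three. Compound 4 `Cc1ccc(S/C(=C/c2ccc(Oc3ccccc3)cc2)C(=O)c2ccc(Br)cc2)cc1` differs from compound 3 in one place: bromo in place of chloro on an aromatic carbon. Among the compounds with values here, the only measured step, a 10-fold higher number from compound 2 to compound 3 (1.00 log units; beyond the scatter), concerns the sulfur-bearing group, so it does not test a halogen swap. The (4-bromophenyl)carbonyl already occurs in compound 1, at 10000 nM, but that compound also differs elsewhere. No step beyond the scatter is therefore expected in this assay. The expected change is no change at the digits printed from compound 3 to compound 4 (within the scatter). Compound 4 is estimated at 10000 nM, with an expected range of 4000 nM to 25000 nM.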

Compound 4, concentration for 50% growth inhibition: 1000 nM
Compound 4: the middle estimate sits 10-fold (1.00 log units) above what was measured, outside the stated range (below it).
By their numbers in this assay, from the lowest: compounds 2 and 4 (each within the scatter of the next); then compounds 1 and 3 (each within the scatter of the next).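

In this assay, changing (4-chlorophenyl)carbonyl to (4-bromophenyl)carbonyl gives a 10-fold lower number from compound 3 to compound 4 (1.00 log units; beyond the scatter), so a swap of one halogen for another at this position is enough to move the number beyond the scatter. With bromo held constant, phenoxy in place of chloro gives a 10-fold lower number from compound 1 to compound 4 (1.00 log units; beyond the scatter), showing that this second site also matters when the sulfanyl link is kept.

Still open, from the compounds shown here alone, is how fluoro, methoxy or an amine would compare with bromo at this position, and whether a sulfonyl link would change the number for the bromo compound. Nothing measured here offers a reason for either step.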